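From 2-(trifluoromethoxy)phenyl to 3-fluorophenyl on the shared core

The source may hold more compounds than are shown below. What is called first, only, known or untested is meant among the compounds shown, and "the series" means these compounds.

In a functional assay on HeLa cells (Homo sapiens) for antiproliferative activity, read by MTT assay, with a stated time of 72 h (a higher number here means a weaker inhibitor, a lower number a stronger inhibitor), compound 1 (`CCCNC(=O)c1cc(Oc2ccc(NC(=O)c3nn(-c4ccc(C)cc4)c(=O)cc3C)cc2F)ccn1`) gives 14200 nM while compound 2 (`CNC(=O)c1cc(Oc2ccc(NC(=O)c3nn(-c4ccccc4Cl)c(=O)cc3C)cc2F)ccn1`) gives 9870 nM and compound 3 (`CCCNC(=O)c1cc(Oc2ccc(NC(=O)c3nn(-c4ccccc4OC(F)(F)F)c(=O)cc3C)cc2F)ccn1`) gives 3690 nM as the lowest number of the three. Compound 3 is therefore the strongest inhibitor measured so far, with both other compounds beyond the usual scatter from it.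

Compound 4 (`CCCNC(=O)c1cc(Oc2ccc(NC(=O)c3nn(-c4cccc(F)c4)c(=O)cc3C)cc2F)ccn1`) differs from compound 3 in one group (3-fluorophenyl in place of 2-(trifluoromethoxy)phenyl on an aromatic nitrogen) and keeps everything else. The group that enters, 3-fluorophenyl, has fewer heavy atoms than the one that leaves, and it sits on the same aromatic nitrogen.

Going by the values given here, only one measured step changes this position while the rest of the molecule stays the same. That step is a 3.8-fold lower number from compound 1 to compound 3 (0.59 log units; beyond the scatter) when 2-(trifluoromethoxy)phenyl takes the place of 4-methylphenyl. Among the compounds with values here, no measured compound carries 3-fluorophenyl, so this single modest step is the only guide to size. Compound 4 gives up the group found in the compound with the lowest number, so a rise is expected, probably no larger than that earlier step. The expected change is a 2.2-fold higher number from compound 3 to compound 4 (0.34 log units; beyond the scatter) in this assay on this limited evidence. Compound 4 is estimated at 8000 nM with an expected range from 3000 nM to 20000 nM in this assay for now.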

Compound 4, half-maximal inhibitory concentration: 6660 nM
Beside the measured number, compound 4's estimate is 1.2-fold (0.08 log units) above it; the range from low to high includes it.
By their numbers in this assay, from the lowest: compounds 3, 4, 2 and 1 (each within the scatter of the next, the first and the last beyond it).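

In this assay, putting 3-fluorophenyl in place of 2-(trifluoromethoxy)phenyl gives a 1.8-fold higher number from compound 3 to compound 4 (0.26 log units; within the scatter), so compound 3 and compound 4 cannot be told apart, even though the entering group has fewer heavy atoms and no hydrogen-bond acceptor. Going by these compounds alone, putting 3-fluorophenyl in place of 4-methylphenyl gives a 2.1-fold lower number from compound 1 to compound 4 (0.33 log units; beyond the scatter), so 2-(trifluoromethoxy)phenyl is no longer the only group on this aromatic nitrogen that separates from 4-methylphenyl beyond the scatter. Nothing available explains why these groups give these numbers.

Each of the three groups compared here differs from the others in both the substituent and where it sits on the phenyl ring, so the effects of substituent identity and placement remain tangled together. On these data alone, it also remains open how this position would respond to a phenyl ring with no substituent, or to one carrying an amine or a carboxylic acid, and whether any such group would move the number further than the steps seen so far.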